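Aryl swap on the hydrazone arm: cytotoxicity outlook

The source may report more compounds than this note shows. Statements on the series, on what has been measured and on what is new or still open speak of the compounds shown alone.

Compound 1 `COc1ccccc1-c1nnc(-c2ccc(C(=O)N/N=C/c3cccc(O)c3O)cc2)o1` and compound 2 `COc1ccccc1-c1nnc(-c2ccc(C(=O)N/N=C/c3ccc(Cl)cc3Cl)cc2)o1` share one core. In an ADME assay on THP-1 cells (Homo sapiens) for cytotoxicity (on this read-out higher numbers stand for weaker inhibition and lower numbers for stronger inhibition), compound 1 gives 102000 nM, the top of the two numbers shown, though only by a gap within the scatter. Compound 2 gives 78800 nM, so the step is a 1.3-fold lower number from compound 1 to compound 2 (0.11 log units; within the scatter). Compound 3 `COc1ccccc1-c1nnc(-c2ccc(C(=O)N/N=C/c3ccccc3[N+](=O)[O-])cc2)o1` differs from compound 1 by 2-nitrophenyl in place of 2,3-dihydroxyphenyl on a carbon with a double bond to nitrogen. For the measured compounds named here, the one step that bears on this is the ring exchange already seen on the same carbon, which stayed within the scatter. The expected step is therefore a 1.2-fold lower number from compound 1 to compound 3 (0.08 log units; within the scatter), nothing beyond the scatter. Compound 3 is estimated at 85000 nM, with a range from 40000 nM to 180000 nM.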

Compound 3, half-maximal inhibitory concentration: 161000 nM
Compound 3: middle estimate off by 1.9-fold (0.28 log units), on the low side, within the range that was stated.
By their numbers in this assay, from the lowest: compounds 2, 1 and 3 (each within the scatter of the next, the first and the last beyond it).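

For the compounds shown here, on this carbon, 2-nitrophenyl gives the only step in this assay that lies beyond the scatter, and it is modest: a 2.0-fold higher number from compound 2 to compound 3 (0.31 log units; beyond the scatter). Against 2,3-dihydroxyphenyl the same group stays within the scatter, with a 1.6-fold higher number from compound 1 to compound 3 (0.20 log units; within the scatter), so the ring exchange at this position matters in one pair only. Nothing available accounts for the gap between 2-nitrophenyl and 2,4-dichlorophenyl. 

Still open, as far as these compounds go, is whether an amine or a carboxylic acid on this ring would shift the number further than these substituents do. From the compounds shown here alone, a longer chain in place of the ring is equally untested here, so the reach of this position remains unknown.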